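The compounds below may be only part of what the source reports. "The series", "measured", "known", "first", "only" and "open" are said of these compounds alone.

Of the compounds shown here, three of the shared core have been measured in a functional assay on H157 cells (Homo sapiens) for antiproliferative activity, read by trypan blue exclusion; on this read-out higher numbers stand for weaker inhibition and lower numbers for stronger inhibition. Compound 1, `COc1cc(OC)c(/C=C/S(=O)(=O)Cc2ccc(C#N)cc2)c(OC)c1`, gives 15000 nM in this assay. Compound 2, `COc1ccc(CS(=O)(=O)/C=C/c2ccc(C)cc2C)cc1`, gives 15000 nM in this assay, level with compound 1 at the digits shown and within the scatter of it. Compound 3, `COc1ccc(CS(=O)(=O)/C=C/c2cc(OC)c(OC)cc2OC)cc1`, returns only a limit in this assay, > 20000 nM, which is not a number; that reading is the limit of > 20000 nM in this assay, at which 1 of the 3 values shown sits.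

Compound 4, `COc1ccc(CS(=O)(=O)/C=C/c2c(C)cc(C)cc2C)cc1`, has not yet been measured. It differs from compound 2 in one place: methyl in place of hydrogen on an aromatic carbon. A methyl takes the place of a hydrogen on an aromatic carbon, ortho to a large group and meta to two methyl groups. Going by the values given here, no measured pair of compounds differs in a single place, and no step of this kind has been observed. Among the compounds with values here, compound 1 and compound 2 carry different substituents yet sit at the same value, and compound 3 gave only a limit; the numbers so far give no sign that a single added methyl would move the read-out beyond the scatter. The expected step is no change at the digits printed from compound 2 to compound 4 (within the scatter), none beyond the scatter. For compound 4 the estimate in this assay is 15000 nM, with a range from 6000 nM to 30000 nM.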

Compound 4, half-maximal inhibitory concentration: > 20000 nM
Compound 4: no number, only a limit; the forecaster's own chance of this, stated with the estimate: 35%; middle value at least 1.3-fold (0.12 log units) away from the limit.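

In this assay, the series now has its first step at a single place, methyl in place of hydrogen on an aromatic carbon, ortho to a large group and meta to two methyl groups, and it reads as an at least 1.3-fold higher number from compound 2 to compound 4 (0.12 log units; that floor lies within the scatter). The reading for compound 4 is a limit and not a number, so this step gives only a floor: it does not show a change beyond the scatter, yet it also does not place compound 4 level with compound 2. With this reading, the series holds two limits: the limit of > 20000 nM in this assay, at which 2 of the 4 values shown sit.

The compounds shown leave open what an amine or a hydroxyl on this aromatic carbon would give, and whether either group would return a number rather than a limit. Also open, going by these compounds, is whether the same methyl would give a similar step on the core of compound 1, which carries a nitrile.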